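Aryl amide in place of isopropyl amide on a pyrazole series

A few compounds are considered here, and "the series" means these few. Any claim that something is new, unique, unknown or untested is made for them only; others in the source may bear on it.

Measured so far:
compound 1, `Cc1cc(C(=O)O)nn1Cc1cc(Br)ccc1OCc1ccccc1`, 6.31 nM in an assay on CHO-K1 cells for displacement of a labelled ligand from prostaglandin E2 receptor EP1 subtype (Homo sapiens); on this read-out higher numbers stand for weaker inhibition and lower numbers for stronger inhibition
compound 2, `Cc1cc(C(=O)NC(C)C)nn1Cc1cc(Cl)ccc1OCc1ccccc1`, 126 nM in this assay

Compound 2 stands at the higher of the two numbers measured in this assay; its nearest neighbour is compound 1, whose value is far enough away that the gap lies beyond the scatter. The two compounds differ in more than one place, so nothing more is said of what separates them than what their two values show.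

Compound 3, `Cc1cc(C(=O)Nc2ccc(F)cc2)nn1Cc1cc(Cl)ccc1OCc1ccccc1`, has not yet been measured in this assay. It differs from compound 2 in a single change: 4-fluorophenyl in place of isopropyl on an amide-type nitrogen. Within the data shown here, no measured pair in this set shows this same change, so there is no step to lean on. The expectation is for a modest move toward a lower number, though one that may well stay within the scatter. On that basis compound 3 is estimated at 60 nM, with a range from 12 nM to 300 nM, which means an expected step of a 2.1-fold lower number from compound 2 to compound 3 (0.32 log units; beyond the scatter).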

Compound 3, half-maximal inhibitory concentration: 79.4 nM
The estimate for compound 3 lay 1.3-fold (0.12 log units) below the measured number; the measured number falls inside the stated range.
By their numbers in this assay, from the lowest: compound 1; then compounds 3 and 2 (each within the scatter of the next).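

In this assay, 4-fluorophenyl in place of isopropyl on the amide-type nitrogen gives a 1.6-fold lower number from compound 2 to compound 3 (0.20 log units; within the scatter), so the two groups cannot be told apart on this read-out. Among these compounds, this is the first comparison in the set that changes only this group, and it shows that the position can carry a six-membered aromatic ring in place of a small branched group with no change beyond the scatter. No separate measurement here offers an explanation for this result.

The compounds shown leave open whether this tolerance extends to other groups on the same nitrogen: a plain phenyl, a benzyl, a longer chain or a morpholine amide would show how far it reaches and whether the fluorine has any part in it. Compound 1 differs from both amides in more than one place, carrying a carboxylic acid and a bromine where they carry an amide and a chlorine, so a close partner with just one of these changes, such as the chlorine-bearing carboxylic acid, would be needed to say what separates it from them.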